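The source may report more compounds than this note shows. Statements on the series, on what has been measured and on what is new or still open speak of the compounds shown alone.

Measured compounds:
compound 1 `COc1cc(-c2cc(/C=C/C(=O)c3ccc(N)cc3)[nH]n2)cc(OC)c1OC`: 99%
compound 2 `COc1ccc(C(=O)/C=C/c2cc(-c3cc(OC)c(OC)c(OC)c3)n[nH]2)cc1OC`: 93%
compound 3 `COc1ccc(C(=O)/C=C/c2cc(-c3cc(OC)c(OC)c(OC)c3)n[nH]2)cc1`: 91%

In a functional assay on SF-268 cells (Homo sapiens) for cytotoxicity, read by sulforhodamine B assay, with a stated time of 48 h, tested at 0.01 uM (on this read-out lower numbers stand for a stronger effect and higher numbers for a weaker effect at the one concentration tested), compound 2 stands second highest of the three numbers. Its nearest neighbour is compound 3, with a number 2 percentage points lower from compound 2 to compound 3 (within the scatter), and its furthest is compound 1, with a number 6 percentage points lower from compound 1 to compound 2 (within the scatter). Neither gap is beyond the scatter, so the three measured compounds cannot be separated on this read-out.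

Compound 4 `COc1cc(C(=O)/C=C/c2cc(-c3cc(OC)c(OC)c(OC)c3)n[nH]2)cc(OC)c1OC` is the next member. methoxy in place of hydrogen on an aromatic carbon The entering methoxy sits ortho to a methoxy group and meta to a large group.

The step that bears most directly on this change is the one in the other direction, a number 2 percentage points lower from compound 2 to compound 3 (within the scatter), where a methoxy was removed from the same ring without any movement beyond the scatter. The step of a number 8 percentage points lower from compound 1 to compound 3 (within the scatter), a change on the same ring, was likewise within the scatter. No measured change on this ring has moved the number beyond the scatter, so no step beyond the scatter is expected here either: no change at the digits printed from compound 2 to compound 4 (within the scatter) is the expected step. Compound 4 is therefore estimated at 93%, with a range from 84% to 100%.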

Compound 4, a percentage reported as activity, at one concentration (the size of the read-out at that concentration, not a potency): 99%
For compound 4 the middle estimate is 6 percentage points below the measured one; the measured number falls inside the stated range.
By their numbers in this assay, from the lowest: compounds 3, 2, 1 and 4 (each within the scatter of the next).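

In this assay, methoxy in place of hydrogen on this aromatic carbon, ortho to a methoxy group, gives a number 6 percentage points higher from compound 2 to compound 4 (within the scatter). Read with a number 2 percentage points lower from compound 2 to compound 3 (within the scatter), this means that from compound 2 both the addition and the removal of a methoxy on this ring now stay within the scatter, so the methoxy addition adds no separation to the series on this read-out. No accompanying measurement bears on this result.

From the compounds shown here alone, whether a different group on this carbon, such as a hydroxyl or a chlorine atom, would give a step beyond the scatter remains open. Also open, going by these compounds, is whether the compounds would separate at any concentration other than the single one tested.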